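A formyl group on compound 1

This account rests on a few compounds, and the source may have more. Where it says the series, first, only, none or still open, it means among the compounds named here.

Within the data shown here, in a functional assay on SK-N-MC cells (Homo sapiens) for cytotoxicity, read by MTT assay, with a stated time of 72 h (on this read-out lower numbers stand for stronger inhibition and higher numbers for weaker inhibition), compound 1 `O=c1[nH]c(/C=C/c2ccccc2)nc2ccccc12` gives 1390 nM, the only exact number so far. Compound 2 `O=c1[nH]c(/C=C/c2ccccc2Br)nc2ccccc12` is reported only as a limit, > 6250 nM. Compound 3 `O=c1[nH]c(/C=C/c2cccc(Cl)c2)nc2ccccc12` is likewise reported only as a limit, > 6250 nM.

Compound 4 `O=Cc1ccc(/C=C/c2nc3ccccc3c(=O)[nH]2)cc1` keeps the structure of compound 1 apart from one change: formyl in place of hydrogen on an aromatic carbon. Among the measured compounds shown here, two measured steps bear on it, as each also replaces hydrogen on an aromatic carbon. Bromo gives an at least 4.4-fold higher number from compound 1 to compound 2 (0.65 log units; beyond the scatter), and chloro gives an at least 4.4-fold higher number from compound 1 to compound 3 (0.65 log units; beyond the scatter). Neither step has an exact size, as both end at the limit of > 6250 nM in this assay, at which 2 of the 3 values shown sit. Bromo and chloro are not formyl, and two examples make only a loose guide, but both point the same way. A move to a higher number, meaning weaker inhibition, is therefore expected in this assay, an estimated 2.9-fold higher number from compound 1 to compound 4 (0.46 log units; beyond the scatter). For compound 4 the estimated value is 4000 nM, with an expected range from 1200 nM to 13000 nM.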

Compound 4, half-maximal inhibitory concentration: > 6250 nM
Compound 4: a limit, no number (the forecaster's own chance of this, stated with the estimate: 45%); at least 1.5-fold (0.19 log units) between middle value and limit.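

In this assay, formyl on an aromatic carbon, para to a large group, gives an at least 4.4-fold higher number from compound 1 to compound 4 (0.65 log units; beyond the scatter). Formyl is not a halogen, so the move to weaker inhibition seen with bromo in compound 2 and chloro in compound 3 is not confined to halogens: all three substituted compounds shown go the same way, and none goes against it. The three cannot be ranked against one another, as each is reported only as the same limit and not as a number: the limit of > 6250 nM in this assay, at which 3 of the 4 values shown sit.

The compounds shown leave open whether an amine, a hydroxyl or a carboxylic acid at this para position would also weaken inhibition, or would hold it near the level of compound 1. They also leave open how bromo or chloro would behave at this same position.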